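Chloro for fluoro with the phenyl kept

The source may hold more compounds than are shown below. What is called first, only, known or untested is meant among the compounds shown, and "the series" means these compounds.

In an ADME assay on BJ cells (Homo sapiens) for cytotoxicity, read by MTT assay, with a stated time of 72 h (on this read-out lower numbers stand for higher toxicity in this test and higher numbers for lower toxicity in this test), compound 1 (`OC[C@H]1O[C@@H](n2cc(F)c3c(-c4ccccc4)ncnc32)[C@H](O)[C@@H]1O`) gives > 50000 nM as a limit and not a number. Compound 1 thus stands at the limit of > 50000 nM in this assay, at which 1 of the 2 values shown sits, on this scale. In this assay compound 2 (`OC[C@H]1O[C@@H](n2cc(F)c3c(-c4cccs4)ncnc32)[C@H](O)[C@@H]1O`) gives 170 nM as a measured number. Among the measured compounds shown here, the one measured step (an at least 290-fold lower number from compound 1 to compound 2 (2.46 log units; beyond the scatter)) is large, but it replaces the phenyl and bears only indirectly on the halogen. Compound 3 (`OC[C@H]1O[C@@H](n2cc(Cl)c3c(-c4ccccc4)ncnc32)[C@H](O)[C@@H]1O`) keeps the phenyl and has chloro in place of fluoro on an aromatic carbon. For the measured compounds named here, no measured step covers this swap, so in this assay only a small shift toward lower numbers is expected (an at least 1.4-fold lower number from compound 1 to compound 3 (0.15 log units; that floor lies within the scatter)) and a result at the limit again is likely. For compound 3 the estimate is 35000 nM (expected range 8000 nM to 50000 nM).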

Compound 3, half-maximal cytotoxic concentration: 44500 nM
For compound 3 the middle estimate is 1.3-fold (0.10 log units) below the measured one; low and high end bracket the measured number.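

In this assay, chloro in place of fluoro on this aromatic carbon of the five-membered ring, with the phenyl kept, gives an at least 1.1-fold lower number from compound 1 to compound 3 (0.05 log units; that floor lies within the scatter). Compound 3 gives the phenyl compounds a measured number on this scale, yet the floor of the step does not leave the scatter. Compound 1 remains a limit and not a number, so the true size of the step cannot be read: the limit of > 50000 nM in this assay, at which 1 of the 3 values shown sits.

Going by these compounds, whether chloro behaves the same way with the thiophen-2-yl kept remains open. So does the effect of an amine or a methyl group on this carbon.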